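Thiophen-2-yl for furan-3-yl on the way to compound 3

The source may hold more compounds than are shown below. What is called first, only, known or untested is meant among the compounds shown, and "the series" means these compounds.

In a functional assay on CCRF-CEM cells (Homo sapiens), read by MTT assay, with a stated time of 72 h (on this read-out lower numbers stand for stronger inhibition and higher numbers for weaker inhibition), compound 2 `Cc1nc(N)c2c(-c3ccoc3)cn([C@@H]3O[C@H](CO)[C@@H](O)[C@H]3O)c2n1` gives > 100000 nM as a limit and not a number. Compound 1 `Nc1nc(N)c2c(-c3cccs3)cn([C@@H]3O[C@H](CO)[C@@H](O)[C@H]3O)c2n1` gives > 20000 nM as a limit too, so no measured number anchors this series yet. Compound 3 `Cc1nc(N)c2c(-c3cccs3)cn([C@@H]3O[C@H](CO)[C@@H](O)[C@H]3O)c2n1` carries thiophen-2-yl in place of furan-3-yl on an aromatic carbon of the shared core. The expected change an at least 2.5-fold lower number from compound 2 to compound 3 (0.39 log units; beyond the scatter) is modest and towards stronger inhibition, and a further limit is quite likely. The estimated value for compound 3 is 40000 nM within an expected range of 8000 nM to 100000 nM in this read-out.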

Compound 3, half-maximal inhibitory concentration: > 20000 nM
Compound 3: a limit, no number; the forecaster's own chance of this, stated with the estimate: 65%; the middle value does not contradict the limit.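

Compound 3 gives > 20000 nM, a limit and not a number. Compound 1 and compound 2 are limits too, so neither step to compound 3 can be read. The compounds shown leave open what number, if any, this series reaches on these cells.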